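From Thiophen-2-yl to 1H-Indol-5-yl on a Shared Core

A few compounds are considered here, and "the series" means these few. Any claim that something is new, unique, unknown or untested is made for them only; others in the source may bear on it.

Compound 1 `O[C@H](COCCOC[C@@H](O)Cc1cn(-c2cccs2)nn1)Cc1ccc(-c2ccccc2)cc1` was tested in a functional assay on SGC-7901 cells (Homo sapiens) for inhibition, read by MTT assay, with a stated time of 72 h (a lower number here means a stronger inhibitor of growth, a higher number a weaker inhibitor of growth), where compound 1 gives 33400 nM, the higher of the two numbers recorded. Compound 2 `O[C@H](COCCOC[C@@H](O)Cc1cn(Cc2cccc(-c3ccccc3)c2)nn1)Cc1ccc(-c2ccccc2)cc1` gives 10600 nM in this assay, a lower number beyond the scatter, though the two compounds differ in more than one place. Compound 3 `O[C@H](COCCOC[C@@H](O)Cc1cn(-c2ccc3[nH]ccc3c2)nn1)Cc1ccc(-c2ccccc2)cc1` is not yet measured in this assay; it differs from compound 1 in one place: 1H-indol-5-yl in place of thiophen-2-yl on an aromatic nitrogen. Among the compounds with values here, no single-place step between measured compounds is available, so a modest move toward stronger inhibition is expected because compound 2, which carries a larger group, gives 10600 nM. Compound 3 is therefore expected to show a 2.2-fold lower number from compound 1 to compound 3 (0.35 log units; beyond the scatter), with an estimated value of 15000 nM ranging from 5000 nM to 50000 nM.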

Compound 3, concentration for 50% growth inhibition: 45600 nM
Compound 3: middle estimate off by 3.0-fold (0.48 log units), on the low side; measured number inside the range.
By their numbers in this assay, from the lowest: compound 2; then compounds 1 and 3 (each within the scatter of the next).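

In this assay, the single-place change on the aromatic nitrogen gives a 1.4-fold higher number from compound 1 to compound 3 (0.14 log units; within the scatter), so thiophen-2-yl and 1H-indol-5-yl cannot be told apart here. Within the data shown here, this is the first direct reading at this position, and it shows that the added six-membered aromatic ring and hydrogen-bond donor of 1H-indol-5-yl do not separate the two compounds in this assay. Nothing at hand offers a reason for this result. On these data alone, what remains open is whether a carboxylic acid or an aminoethyl chain on this aromatic nitrogen would move the number beyond the scatter.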